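Swapping methoxy for fluoro on the shared core

The compounds below may be only part of what the source reports. "The series", "measured", "known", "first", "only" and "open" are said of these compounds alone.

Of the compounds shown here, three sharing one core have been tested in a functional assay on HT-29 cells (Homo sapiens) for cytotoxicity, read by MTT assay, with a stated time of 48 h (a higher number here means a weaker inhibitor, a lower number a stronger inhibitor), so far. Compound 1 (`Cc1ccc(C2=NO[C@@H]3[C@H](CO)C[C@H](CO)[C@H]23)cc1`), with methyl on its aromatic ring, reads > 50 ug/mL as a limit and not a number. Compound 2 (`OC[C@@H]1C[C@H](CO)[C@@H]2C(c3ccc(Br)cc3)=NO[C@H]12`), with bromo there, gives 37.3 ug/mL as a true number. Compound 3 (`COc1ccc(C2=NO[C@@H]3[C@H](CO)C[C@H](CO)[C@H]23)cc1`), with methoxy, also reads only a limit of > 50 ug/mL and so stands at the limit of > 50 ug/mL in this assay, at which 2 of the 3 values shown sit, in the data.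

Compound 4 (`OC[C@@H]1C[C@H](CO)[C@@H]2C(c3ccc(F)cc3)=NO[C@H]12`) makes one change to compound 3: fluoro in place of methoxy on an aromatic carbon. Here fluoro replaces methoxy on an aromatic carbon, the same carbon that varies across the three tested compounds. Changes there gave an at least 1.3-fold lower number from compound 1 to compound 2 (0.12 log units; that floor lies within the scatter), then an at least 1.3-fold higher number from compound 2 to compound 3 (0.12 log units; that floor lies within the scatter) and a step that the two limits leave unreadable from compound 1 to compound 3. None of these is shown to exceed the scatter, so no clear shift is expected in this assay, and the expected change is an at least 1.1-fold lower number from compound 3 to compound 4 (0.04 log units; that floor lies within the scatter). Compound 4 is estimated at 45 ug/mL, with an expected range from 25 ug/mL to 80 ug/mL.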

Compound 4, half-maximal inhibitory concentration: 17.8 ug/mL
The estimate for compound 4 lay 2.5-fold (0.40 log units) above the measured number; the whole stated range lies above it.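

In this assay fluoro in place of methoxy gives an at least 2.8-fold lower number from compound 3 to compound 4 (0.44 log units; beyond the scatter) and fluoro in place of methyl gives an at least 2.8-fold lower number from compound 1 to compound 4 (0.44 log units; beyond the scatter) so this aromatic carbon can move the read-out beyond the scatter. Fluoro in place of bromo gives a 2.1-fold lower number from compound 2 to compound 4 (0.32 log units; beyond the scatter) so the two halogens are also told apart, and compound 4 is the only compound here whose steps to all the others lie beyond the scatter. Because compound 1 and compound 3 read only as limits, two of these steps are floors and their true size may be larger: the limit of > 50 ug/mL in this assay, at which 2 of the 4 values shown sit.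

Only four groups on this carbon are shown, so it stays open whether chloro, an amine or a carboxylic acid would read closer to fluoro or to methoxy. Nothing here shows why fluoro stands apart, or how a change elsewhere on the shared core would read.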